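The compounds below may be only part of what the source reports. "The series", "measured", "known", "first", "only" and "open" are said of these compounds alone.

In a functional assay on A549 cells (Homo sapiens) for inhibition, read by MTT assay, with a stated time of 48 h (a lower number here means a stronger inhibitor, a higher number a weaker inhibitor), compound 1 `COc1ccc(N(C)c2nc(C)nc3ccccc23)cc1OCCCCCC[Se]C#N` gives 5520 nM, compound 3 `COc1ccc(N(C)c2nc(C)nc3ccccc23)cc1C(=O)OCCC[Se]C#N` gives 250 nM and compound 2 `Cc1nc(N(C)c2ccc([Se]C#N)c(C)c2)c2ccccc2n1` gives 8 nM, the lowest of the three numbers and clearly apart from both others. Compound 4 `Cc1nc(N(C)c2ccc([Se]C#N)c(F)c2)c2ccccc2n1` differs from compound 2 by fluoro in place of methyl on an aromatic carbon.

For the measured compounds named here, no measured pair makes this exchange. Going by the values given here, the one measured step, a 22-fold lower number from compound 1 to compound 3 (1.34 log units; beyond the scatter), is large, but it replaces one much bigger group with another, so it bears only loosely on a swap of single atoms. It does show that the series can respond strongly to a change in substituent, which argues for a wide range. Compound 2 already stands very low at 8 nM, so a small move toward a higher number in this assay is expected, possibly no more than the scatter. The estimated change is a 1.9-fold higher number from compound 2 to compound 4 (0.27 log units; within the scatter). For compound 4 the expected value is 15 nM, with an estimated range of 4 nM to 60 nM.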

Compound 4, half-maximal inhibitory concentration: 4 nM
Compound 4: the middle estimate sits 3.8-fold (0.57 log units) above what was measured, within the range that was stated.
By their numbers in this assay, from the lowest: compounds 4 and 2 (each within the scatter of the next); then compound 3; then compound 1.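

In this assay, a 2.0-fold lower number from compound 2 to compound 4 (0.30 log units; within the scatter) is the only single-atom exchange shown, and it lies within the scatter, so methyl and fluoro are not told apart on this aromatic carbon. The earlier step, a 22-fold lower number from compound 1 to compound 3 (1.34 log units; beyond the scatter), replaced one large group with another and said nothing about this position; here, both of these one-atom groups leave the number low. Nothing measured on these compounds accounts for the match between the two groups.

Only these two groups are shown on this carbon, so it remains open whether the low number would hold with a larger or different group, such as trifluoromethyl, an amine or a carboxylic acid. Going by these compounds, whether the same exchange would also leave the number unmoved on the core of compound 1 or compound 3 remains open too.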